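Furan to phenyl on the amide carbonyl in a pyrazolopyrimidine series

This account rests on a few compounds, and the source may have more. Where it says the series, first, only, none or still open, it means among the compounds named here.

Compound 2 `O=C(Nc1nc(-c2ccccc2)nc2cn(-c3ccccc3)nc12)c1ccco1` stands lowest of the two values known in an assay on CHO cells for displacement of a labelled ligand from adenosine receptor A1 (Homo sapiens), read by scintillation counting, with a stated time of 120 min, tested at 1 uM; a higher number here means more inhibition at the concentration tested (going by the name of the read-out), a lower number less inhibition: compound 2 gives 11%, while compound 1 `Cc1nc(NC(=O)c2ccccc2)c2nn(-c3ccccc3)cc2n1` gives 30%, a gap beyond the scatter. Compound 3 `O=C(Nc1nc(-c2ccccc2)nc2cn(-c3ccccc3)nc12)c1ccccc1` differs from compound 2 only at the carbonyl carbon, (phenyl in place of furan-2-yl on a carbonyl carbon). Among the measured compounds shown here, no measured pair shows this change on this core, so its size is unknown; compound 1 carries the benzamido group on a core that differs elsewhere, so its value tells nothing directly. The step from compound 2 to compound 3 is expected to be small to moderate, upward, a number 9 percentage points higher from compound 2 to compound 3 (within the scatter). Compound 3 is estimated at 20%, within 5% to 40%.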

Compound 3, a percentage reported as inhibition, at one concentration (the size of the read-out at that concentration, not a potency): 5%
Compound 3: middle estimate off by 15 percentage points, on the high side; low and high end bracket the measured number.
By their numbers in this assay, from the lowest: compounds 3 and 2 (each within the scatter of the next); then compound 1.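

In this assay, phenyl in place of furan-2-yl on the carbonyl carbon gives a number 6 percentage points lower from compound 2 to compound 3 (within the scatter) and so leaves no readable effect of this change on the shared core. Among the compounds shown here, the first one-place comparison at the aromatic carbon, phenyl in place of methyl, gives a number 25 percentage points lower from compound 1 to compound 3 (beyond the scatter) and marks that site as the one that responds so far. No available evidence explains either step.

On these data alone, whether a longer chain or an amine on the aromatic carbon moves the number beyond the level of compound 1 stays open. Also open, as far as these compounds go, is whether an amine in place of the ring on the carbonyl carbon would produce a readable step.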